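Hydroxy for Chloro on the Anilino Ring

The source may hold more compounds than are shown below. What is called first, only, known or untested is meant among the compounds shown, and "the series" means these compounds.

Compound 1 `N#Cc1c(Cl)nc(SCC(=O)Nn2c(COc3ccc(Cl)cc3Cl)nc3ccccc3c2=O)nc1-c1ccc(Cl)cc1` gives 68.4% in a functional assay on the whole organism (strain albino) for inhibition, with Rattus norvegicus as the target, read by paw edema, with stated times of 1 h and 2 h, at a dose of 100 mg/kg by the oral route; on this read-out lower numbers stand for less inhibition and higher numbers for more inhibition at the one dose given (going by the name of the read-out).
Compound 2 `N#Cc1c(Nc2ccc(O)cc2)nc(SCC(=O)Nn2c(COc3ccc(Cl)cc3Cl)nc3ccccc3c2=O)nc1-c1ccccc1` gives 59.7% in this assay.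
Compound 3 `N#Cc1c(Nc2ccc(Cl)cc2)nc(SCC(=O)Nn2c(COc3ccc(Cl)cc3Cl)nc3ccccc3c2=O)nc1-c1ccc(Cl)cc1` gives 61.4% in this assay.

Compound 3 stands second highest of the three numbers, within the scatter of both compound 2, the nearest, and compound 1, the furthest. Compound 4 `N#Cc1c(Nc2ccc(O)cc2)nc(SCC(=O)Nn2c(COc3ccc(Cl)cc3Cl)nc3ccccc3c2=O)nc1-c1ccc(Cl)cc1` differs from it by hydroxy in place of chloro on an aromatic carbon. Within the data shown here, no measured step carries this change. Among the measured compounds shown here, the one measured step, a number 7 percentage points lower from compound 1 to compound 3 (within the scatter), concerns a different position and lies within the scatter. Compound 2 already carries the (4-hydroxyphenyl)amino group, and its value and that of compound 3 lie within the scatter of each other. Compound 4 is therefore expected to show a step of a number 0.4 percentage points lower from compound 3 to compound 4 (within the scatter), none beyond the scatter. Compound 4 is estimated at 61%, between 50% and 72%.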

Compound 4, a percentage reported as inhibition, in the whole organism at one dose (the size of the read-out at that dose, not a potency): 91.2%
Compound 4: middle estimate off by 30.2 percentage points, on the low side; the measured number lies above the stated range.
By their numbers in this assay, from the lowest: compounds 2, 3 and 1 (each within the scatter of the next); then compound 4.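

In this assay, among these compounds, hydroxy in place of chloro at this position gives a number 29.8 percentage points higher from compound 3 to compound 4 (beyond the scatter) and so is the first change here to move the number beyond the scatter. The (4-hydroxyphenyl)amino group does not do this alone, as chloro in place of hydrogen on an aromatic carbon gives a number 31.5 percentage points higher from compound 2 to compound 4 (beyond the scatter) on the same group, while (4-hydroxyphenyl)amino in place of chloro gives a number 22.8 percentage points higher from compound 1 to compound 4 (beyond the scatter) with that chloro kept. Nothing at hand bears on the cause of these steps.

Whether the gain needs hydroxy itself stays open, since methoxy or an amine at this place is not among the compounds shown.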